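Amide-to-urea switch on the shared core, compound 1 to 3

The compounds below may be only part of what the source reports. "The series", "measured", "known", "first", "only" and "open" are said of these compounds alone.

Compound 1 `COc1cc(-c2nn(-c3cccc(NC(=O)c4cccc(C(F)(F)F)c4)c3)cc2-c2ccncc2)ccc1Cl` is the reference point here. In a functional assay on COLO 205 cells (Homo sapiens) for inhibition, read by sulforhodamine B assay, with a stated time of 48 h (a higher number here means a weaker inhibitor of growth, a lower number a stronger inhibitor of growth), compound 1 gives 1640 nM, the lowest of the two numbers recorded so far. Compound 2 `O=C(Nc1cccc(-n2cc(-c3ccncc3)c(-c3ccc(Cl)c(O)c3)n2)c1)Nc1ccc(Cl)c(C(F)(F)F)c1` carries a urea in place of the amide and also differs on the chlorophenyl ring; in this assay compound 2 gives 2390 nM, which sits within the scatter of the number for compound 1, so no ordering between these two can be drawn.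

Compound 3 `COc1cc(-c2nn(-c3cccc(NC(=O)Nc4ccc(Cl)c(Cl)c4)c3)cc2-c2ccncc2)ccc1Cl` has not been measured. Relative to compound 1 the change is (3,4-dichlorophenyl)amino in place of 3-(trifluoromethyl)phenyl on a carbonyl carbon; the amide becomes a carbamoyl that keeps the methoxy substitution of compound 1 untouched. Within the data shown here, since no measured pair isolates this change, the expectation rests on the fact that the urea-bearing compound 2 gives 2390 nM in the same range as compound 1. A step from compound 1 to compound 3 of a 1.2-fold higher number from compound 1 to compound 3 (0.09 log units; within the scatter) is expected, that is, none beyond the scatter. Compound 3 is estimated to give 2000 nM in this assay, within a range from 700 nM to 6000 nM.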

Compound 3, concentration for 50% growth inhibition: 937 nM
Compound 3: middle estimate off by 2.1-fold (0.33 log units), on the high side; the range from low to high includes it.
By their numbers in this assay, from the lowest: compounds 3, 1 and 2 (each within the scatter of the next, the first and the last beyond it).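

In this assay, among these compounds, the one pair differing in a single place gives a 1.8-fold lower number from compound 1 to compound 3 (0.24 log units; within the scatter), so this step shows no readable shift when (3,4-dichlorophenyl)amino replaces 3-(trifluoromethyl)phenyl on a carbonyl carbon. Among the compounds shown here, this is the first view of the (3,4-dichlorophenyl)carbamoyl group on the core of compound 1 with the methoxy group kept, whereas compound 2 carried its urea together with a further difference on the chlorophenyl ring and so could not speak for the urea alone. No supporting measurement on the compounds bears on this result, and no explanation can be attached to it.

The step combines the new amino nitrogen with the exchange of trifluoromethyl for two chlorines, and the share of each cannot be read from these compounds. On these data alone, it remains open whether a cyclohexylamino group at this carbonyl carbon, or a morpholine or carboxylic acid on the terminal phenyl ring, would move the number in this assay beyond the scatter.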